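What a shorter saturated chain should do

The compounds below may be only part of what the source reports. "The series", "measured", "known", "first", "only" and "open" are said of these compounds alone.

Compound 1 `CCCCCCCCCCCCCC=C(C(=O)OCC)C(=O)OCC` gives 42900 nM
Compound 2 `CCCCCCCCCCCCCCC=C(C(=O)OCC)C(=O)OCC` gives 44900 nM
Compound 3 `CCCCCCCCCCC=C(C(=O)OCC)C(=O)OCC` has not yet been measured

In a functional assay on U-937 cells (Homo sapiens) for activation, read by flow cytometry, annexin V staining and propidium iodide staining, with a stated time of 30 h (a lower number here means a stronger inhibitor, a higher number a weaker inhibitor), compound 2 gives 44900 nM and stands level with compound 1 within the scatter. Compound 3 differs from compound 2 by hydrogen in place of butyl on a saturated chain carbon, ten or more bonds along the chain from a double-bonded chain carbon. Among the compounds with values here, only one measured step bears on this: a 1.0-fold higher number from compound 1 to compound 2 (0.02 log units; within the scatter), for methyl in place of hydrogen at that place. The change here is larger, so a modest move toward a higher number in this assay is expected, though that single step fixes no direction. The estimated step is a 1.3-fold higher number from compound 2 to compound 3 (0.13 log units; within the scatter). Compound 3 is expected at 60000 nM, within an estimated range of 28000 nM to 130000 nM.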

Compound 3, half-maximal inhibitory concentration: 156000 nM
Estimate against measurement, compound 3: 2.6-fold (0.41 log units) below, and the stated range ends below it.
By their numbers in this assay, from the lowest: compounds 1 and 2 (each within the scatter of the next); then compound 3.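

In this assay, the far end of the chain proved sensitive to length after all: hydrogen in place of butyl gives a clear rise in the number (a 3.5-fold higher number from compound 2 to compound 3 (0.54 log units; beyond the scatter)), and hydrogen in place of propyl gives a similar one (a 3.6-fold higher number from compound 1 to compound 3 (0.56 log units; beyond the scatter)). The single added methyl separating compound 1 and compound 2 had shown no such change, so the shift appears only with the larger cut. Nothing measured here accounts for the rise.

The compounds shown leave open how a longer chain would read here, and where along the chain lengths separating compound 3 and compound 1 the number starts to climb. They also leave open whether a carboxylic acid in place of the ethyl esters would change this dependence on chain length.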